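This account rests on a few compounds, and the source may have more. Where it says the series, first, only, none or still open, it means among the compounds named here.

In a functional assay on KB cells (Homo sapiens) for inhibition, read by MTT assay, with a stated time of 24 h, tested at 0.1 ug/mL (a higher number here means more inhibition of growth at the concentration tested, a lower number less inhibition of growth), compound 1 (`O=C(O)CCCCC(CCSC(=O)c1ccccc1)SC(=O)c1ccccc1`) is recorded as "not active" (no number reported), so it offers no single number to measure from. Going by the values given here, the only numerical reading is that of compound 2 (`Cc1cccc(NC(=O)CCCCC(S)CCS)c1`), at 5.75%. Compound 3 (`O=C(CCCCC(CCSC(=O)c1ccccc1)SC(=O)c1ccccc1)Nc1ccc(Cl)cc1`) follows from compound 1 through one change: (4-chlorophenyl)amino in place of hydroxy on a carbonyl carbon, with (4-chlorophenyl)amino in place of hydroxy on a carbonyl carbon. Among the compounds with values here, no measured pair shows the effect of this replacement, so the expectation is loosely held. A modest step upward from compound 1 in this assay is expected, towards low but measurable inhibition of growth, and a second result without a number remains possible. The scale of that expectation rests on compound 2 at 5.75%. In this assay, the expected value for compound 3 is 12%, within an estimated range of 2% to 35%.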

Compound 3, percent growth inhibition at one concentration: 17%
Compound 3: middle estimate off by 5 percentage points, on the low side, within the range that was stated.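

Going by these compounds alone, compound 1 carries no number in this assay and so no step to compound 3 can be read. The compounds shown leave open how far (4-chlorophenyl)amino in place of hydroxy shifts inhibition of growth, and no measured property bears on this result.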